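A few compounds are considered here, and "the series" means these few. Any claim that something is new, unique, unknown or untested is made for them only; others in the source may bear on it.

Compound 2 `N#CC1=C(N)Oc2c(c3nc4ccccc4nc3c3ccccc23)C12C(=O)N(Cc1cnnn1-c1ccc(Br)cc1)c1ccccc12` is the starting point of this step. In a functional assay on MCF7 cells (Homo sapiens) for antiproliferative activity, read by MTT assay, with a stated time of 48 h (a lower number here means a stronger inhibitor, a higher number a weaker inhibitor), compound 2 gives 36600 nM, and compound 1 `N#CC1=C(N)Oc2c(c3nc4ccccc4nc3c3ccccc23)C12C(=O)N(Cc1cnnn1-c1cccc(Cl)c1)c1ccccc12` lies within the scatter of it with 43600 nM. Compound 3 `N#CC1=C(N)Oc2c(c3nc4ccccc4nc3c3ccccc23)C12C(=O)N(Cc1cnnn1-c1cccc(Br)c1)c1ccccc12` gives > 50000 nM in this assay, which is a limit of the measurement rather than a number (the limit of > 50000 nM in this assay, at which 1 of the 3 values shown sits). Compound 4 `N#CC1=C(N)Oc2c(c3nc4ccccc4nc3c3ccccc23)C12C(=O)N(Cc1cnnn1-c1cc(Cl)ccc1Cl)c1ccccc12` alters the group on the aromatic nitrogen: 2,5-dichlorophenyl in place of 4-bromophenyl on an aromatic nitrogen. Two earlier exchanges of that same group changed little, a 1.2-fold lower number from compound 1 to compound 2 (0.08 log units; within the scatter) and an at least 1.3-fold higher number from compound 2 to compound 3 (0.13 log units; that floor lies within the scatter), neither of them beyond the scatter. A 2,5-dichlorophenyl in this position is therefore expected to bring no step beyond the scatter, a 1.1-fold higher number from compound 2 to compound 4 (0.04 log units; within the scatter). Compound 4 is estimated at 40000 nM, between 20000 nM and 80000 nM.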

Compound 4, half-maximal inhibitory concentration: > 50000 nM
Compound 4: a limit, no number; the forecaster's own chance of this, stated with the estimate: 35%; at least 1.2-fold (0.09 log units) between middle value and limit.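

With 2,5-dichlorophenyl, this position carries a second halogen on the phenyl ring, and no stronger inhibition appears: the change gives an at least 1.3-fold higher number from compound 2 to compound 4 (0.13 log units; that floor lies within the scatter), and an at least 1.1-fold higher number from compound 1 to compound 4 (0.05 log units; that floor lies within the scatter). The step between compound 3 and compound 4 cannot be read, as both values are limits. Compound 4 is itself a limit and not a number, and the halogenated phenyl groups now reach it as often as they give a number: the limit of > 50000 nM in this assay, at which 2 of the 4 values shown sit.

All four compounds carry a halogenated phenyl group here. On these data alone, what an unsubstituted phenyl, or a phenyl bearing an amine or a carboxylic acid, would do remains open.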